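A few compounds are considered here, and "the series" means these few. Any claim that something is new, unique, unknown or untested is made for them only; others in the source may bear on it.

Working notes on a set of three measured compounds and one unmeasured analogue, all sharing a fused two-ring core with a chloromethyl-substituted benzyl group on a ring nitrogen.

In a functional assay on NCI-H322M cells (Homo sapiens) for cytotoxicity, read by sulforhodamine B assay, with a stated time of 48 h (on this read-out higher numbers stand for lower toxicity in this test and lower numbers for higher toxicity in this test), compound 1 `ClCc1ccccc1Cn1cnc2c(Cl)nc(Cl)nc21` gives 5880 nM, the lowest number of the three measured. Compound 2 `ClCc1cccc(Cn2cnc3c(Cl)nc(Cl)nc32)c1` gives 15900 nM in this assay, and compound 3 `ClCc1cccc(Cn2cnc3nc(Cl)nc(Cl)c32)c1` gives 52500 nM; both stand beyond the scatter above compound 1.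

Compound 4 `Nc1nc(Cl)c2ncn(Cc3ccccc3CCl)c2n1` differs from compound 1 in one place: amino in place of chloro on an aromatic carbon, on an aromatic carbon of a six-membered aromatic ring with two nitrogens, between two ring nitrogen atoms, meta to a chloro group. Among the compounds with values here, no measured pair in the set reports this exchange, so its size is not known here. With one chloro leaving and an amino entering, a modest shift toward a higher number is expected, though a result within the scatter of compound 1 would not be surprising.

Compound 4 is expected to give 8500 nM in this assay, within a range of 3000 nM to 25000 nM. The step this implies, a 1.4-fold higher number from compound 1 to compound 4 (0.16 log units; within the scatter), is an estimate only.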

Compound 4, concentration lethal to 50% of the cells: 69200 nM
The estimate for compound 4 lay 8.1-fold (0.91 log units) below the measured number; the whole stated range lies below it.
By their numbers in this assay, from the lowest: compound 1; then compound 2; then compounds 3 and 4 (each within the scatter of the next).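

In this assay, amino in place of chloro on the aromatic carbon between two ring nitrogen atoms gives a 12-fold higher number from compound 1 to compound 4 (1.07 log units; beyond the scatter) and so marks a large change in the read-out, toward lower toxicity in this test. The chloro group at this place therefore matters to the result: this single exchange is enough for the large step, with the other chloro group and the chloromethyl-substituted benzyl group unchanged. The data in hand give no explanation for the size of this step.

From the compounds shown here alone, whether a similar step would follow with a methoxy group, a hydroxyl group or a methylamino group at this place remains open. Also open, going by these compounds, is whether amino in place of chloro would give a step of similar size on compound 2 or compound 3.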